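Sulfonamide chain extension across two benzanilide cores

The source may hold more compounds than are shown below. What is called first, only, known or untested is meant among the compounds shown, and "the series" means these compounds.

Of the compounds shown here, three have been read in an ADME assay on HEK293 cells (Homo sapiens) for cytotoxicity, read by MTT assay, with a stated time of 48 h; a higher number here means a weaker inhibitor, a lower number a stronger inhibitor. Compound 1 `Cc1cc(NC(=O)c2cccc(C(F)(F)F)c2)ccc1NS(C)(=O)=O` gives 194000 nM in this assay. Compound 2 `CCS(=O)(=O)Nc1ccc(NC(=O)c2cccc(C(F)(F)F)c2)cc1C` differs from compound 1 by methyl in place of hydrogen on a saturated chain carbon bound to a sulfonyl sulfur, and compound 2 gives 210000 nM; the step is a 1.1-fold higher number from compound 1 to compound 2 (0.03 log units; within the scatter). Compound 3 `CS(=O)(=O)Nc1ccc(NC(=O)c2ccc(Cl)cc2)cc1Cl` gives 167000 nM; the difference between the core of compound 3 and the core of compound 1 is not broken down here. The three measured values lie within the scatter of each other, so nothing separates compound 1, compound 2 and compound 3 in this assay.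

Compound 4 `CCS(=O)(=O)Nc1ccc(NC(=O)c2ccc(Cl)cc2)cc1Cl` has not yet been measured. It differs from compound 3 by methyl in place of hydrogen on a saturated chain carbon bound to a sulfonyl sulfur, the same change as the one from compound 1 to compound 2, and the place is the same in both pairs; the change occurs twice in all among these compounds. The earlier instance, a 1.1-fold higher number from compound 1 to compound 2 (0.03 log units; within the scatter), sits within the scatter. Compound 3 gives 167000 nM, close to compound 1, so the change is expected to do little on the second core as well. The expected step is a 1.1-fold higher number from compound 3 to compound 4 (0.03 log units; within the scatter), because a 1.1-fold higher number from compound 1 to compound 2 (0.03 log units; within the scatter) stayed within the scatter. Compound 4 is expected to give 180000 nM in this assay. The estimate for compound 4 is expected to fall between 100000 nM and 320000 nM.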

Compound 4, half-maximal inhibitory concentration: > 250000 nM
Compound 4 ended at the assay's limit; the forecaster's own chance of this, stated with the estimate: 15%; middle value at least 1.3-fold (0.14 log units) away from the limit.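

In this assay, the change from methylsulfonyl to ethylsulfonyl on the core of compound 3 gives an at least 1.4-fold higher number from compound 3 to compound 4 (0.17 log units; that floor lies within the scatter), a step that can be read only as a floor, with compound 4 standing at a limit of the assay and not at a number. Set beside the same change on the core of compound 1, the result gives no separation between the two cores: the same change on two cores in this assay, a 1.1-fold higher number (0.03 log units; within the scatter) from compound 1 to compound 2 and an at least 1.4-fold higher number (0.17 log units; that floor lies within the scatter) from compound 3 to compound 4; the limit leaves it open whether they differ The series therefore shows that this change has been tried on two cores and that the step on the core of compound 1 stays within the scatter, but it does not show that the change carries over with the same size or that its size depends on the core, and one of the two readings rests on a limit: the limit of > 250000 nM in this assay, at which 1 of the 4 values shown sits.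

Open, going by these compounds, is the true size of the step on the core of compound 3, which a number for compound 4 in place of its limit would be needed to settle. Also open, on these data alone, is whether a longer chain, an amine or a carboxylic acid in place of the ethyl group on the sulfonyl sulfur would give a step beyond the scatter on either core.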